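This account rests on a few compounds, and the source may have more. Where it says the series, first, only, none or still open, it means among the compounds named here.

Measured so far:
compound 1, `O=C(/C=C/c1ccc(Cl)cc1)c1cccc(NC(=O)c2cc(-c3ccncc3)n[nH]2)c1`, 78900 nM in a functional assay, read by spectrophotometry, tested at 100 uM; on this read-out higher numbers stand for weaker inhibition and lower numbers for stronger inhibition;
compound 2, `O=C(/C=C/c1cccs1)c1cccc(NC(=O)c2cc(-c3ccncc3)n[nH]2)c1`, 70000 nM;
compound 3, `COc1ccccc1/C=C/C(=O)c1cccc(NC(=O)c2cc(-c3ccncc3)n[nH]2)c1`, 56700 nM.

Compound 1 carries the highest number of the three, yet neither neighbour is separated from it beyond the scatter: a 1.1-fold lower number from compound 1 to compound 2 (0.05 log units; within the scatter) and a 1.4-fold lower number from compound 1 to compound 3 (0.14 log units; within the scatter). Compound 4, `CC(C)c1ccc(/C=C/C(=O)c2cccc(NC(=O)c3cc(-c4ccncc4)n[nH]3)c2)cc1`, keeps the whole core of compound 1 and changes only the ring at the end of the chain: isopropyl in place of chloro on an aromatic carbon. Going by the values given here, no measured step alters a group on that ring while keeping the ring itself; the measured steps exchange the entire ring, and each stays within the scatter. A change of the size expected here is therefore none beyond the scatter. Compound 4 is expected to give about 72000 nM, within 35000 nM to 150000 nM. The step this estimate implies is a 1.1-fold lower number from compound 1 to compound 4 (0.04 log units; within the scatter).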

Compound 4, half-maximal inhibitory concentration: 60200 nM
Beside the measured number, compound 4's estimate is 1.2-fold (0.08 log units) above it, within the range that was stated.
By their numbers in this assay, from the lowest: compounds 3, 4, 2 and 1 (each within the scatter of the next).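

In this assay, going by these compounds alone, isopropyl in place of chloro, the first change that keeps the ring itself, gives no shift that stands out from the scatter (a 1.3-fold lower number from compound 1 to compound 4 (0.12 log units; within the scatter)), so at this position the two groups cannot be told apart. Comparing whole rings shows the same: (a 1.1-fold higher number from compound 3 to compound 4 (0.03 log units; within the scatter)) and (a 1.2-fold lower number from compound 2 to compound 4 (0.07 log units; within the scatter)) also stay within the scatter. No outside evidence bears on this result. Still open, from the compounds shown here alone, is whether an amine or a carboxylic acid at this position would move the number beyond the scatter.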